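Nitro analogue of a series that only reaches assay limits

This account rests on a few compounds, and the source may have more. Where it says the series, first, only, none or still open, it means among the compounds named here.

Compound 1 `CCOC(=O)c1c(-c2cc(F)cc(OC)c2)[nH]c2cc(OC)ccc2c1=O` was examined in an ADME assay on HEK293 cells (Homo sapiens) for cytotoxicity, read by luminescence, with a stated time of 72 h; on this read-out lower numbers stand for an effect already at smaller amounts and higher numbers for an effect only at larger amounts of compound. In this assay compound 1 gives > 22000 nM, which is a limit of the assay rather than a measured number. Two close relatives share the same core and differ from it only in the attached aromatic group. Compound 2 `CCOC(=O)c1c(-c2ccccc2)[nH]c2cc(OC)ccc2c1=O` carries a plain phenyl; in this assay compound 2 gives > 22000 nM, again a limit. Compound 3 `CCOC(=O)c1c(-c2cccc(OC(F)(F)F)c2)[nH]c2cc(OC)ccc2c1=O` carries a trifluoromethoxy group on its phenyl; in this assay compound 3 gives > 22000 nM, also a limit. Because of the limit of > 22000 nM in this assay, at which 3 of the 3 values shown sit, the two comparisons that can be drawn, a step that the two limits leave unreadable from compound 1 to compound 2 and a step that the two limits leave unreadable from compound 2 to compound 3, have no readable size: neither shows whether the change moved the value at all.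

Compound 4 `CCOC(=O)c1c(-c2cccc([N+](=O)[O-])c2)[nH]c2cc(OC)ccc2c1=O` has not yet been measured. It differs from compound 1 in one place: 3-nitrophenyl in place of 3-fluoro-5-methoxyphenyl on an aromatic carbon. Among the measured compounds shown here, all three measured relatives sit at the same limit, so no measured step tells how a change on this phenyl affects the read-out. The plain expectation is that compound 4 will also reach the limit, so that the expected step that the limit leaves unreadable from compound 1 to compound 4 stays within the scatter. Compound 4 is estimated at 30000 nM, with a range from 15000 nM to 80000 nM.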

Compound 4, half-maximal effective concentration: > 22000 nM
Compound 4: no number, only a limit (the forecaster's own chance of this, stated with the estimate: 85%); the middle value is on the limit's open side.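

In this assay the steps from compound 1, compound 2 and compound 3 to compound 4 cannot be read, because all of them rest on a single limit: the limit of > 22000 nM in this assay, at which 4 of the 4 values shown sit. The compounds shown leave open whether any change to the attached aromatic group moves the read-out, and at what concentration, if any, these four compounds would show an effect.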